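Lengthening the Chain on a Weakly Active Compound

A few compounds are considered here, and "the series" means these few. Any claim that something is new, unique, unknown or untested is made for them only; others in the source may bear on it.

In a functional assay on HCT-116 cells (Homo sapiens) for inhibition, read by MTT assay, with a stated time of 72 h (on this read-out lower numbers stand for stronger inhibition and higher numbers for weaker inhibition), compound 2 `Nc1nc2cc(-c3nn(CCCC(=O)NO)c4ncnc(N)c34)ccc2o1` gives 19600 nM. Compound 1 `Nc1ncnc2c1c(-c1cnc3[nH]ccc3c1)nn2CC(=O)NO` reads > 150000 nM, which is a limit of the assay and not a number. Compound 3 `Nc1nc2cc(-c3nn(CCC(=O)NO)c4ncnc(N)c34)ccc2o1` reads > 100000 nM, and this too is only a limit. Compound 2 is therefore the only one of the three with a true number.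

Compound 4 `Nc1nc2cc(-c3nn(CCCCCCCCC(=O)NO)c4ncnc(N)c34)ccc2o1` differs from compound 3 in one place: 6-(hydroxycarbamoyl)hexyl in place of hydroxycarbamoyl on a saturated chain carbon, two bonds along the chain from an aromatic nitrogen. Here, 6-(hydroxycarbamoyl)hexyl stands in place of hydroxycarbamoyl on a saturated chain carbon, two bonds along the chain from an aromatic nitrogen.

Among the measured compounds shown here, one measured step bears on this change: an at least 5.1-fold higher number from compound 2 to compound 3 (0.70 log units; beyond the scatter). In that step, the shorter chain went with the higher number. This single step suggests that the much longer chain should move the number down, towards stronger inhibition, though the size of so large a change remains uncertain. The expected change is an at least 33-fold lower number from compound 3 to compound 4 (1.52 log units; beyond the scatter). The estimate for compound 4 is 3000 nM, with an expected range of 300 nM to 30000 nM.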

Compound 4, half-maximal inhibitory concentration: 2980 nM
The estimate for compound 4 lay 1.0-fold (0.00 log units) above the measured number; the range from low to high includes it.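

In this assay, the longer chain gives a 6.6-fold lower number from compound 2 to compound 4 (0.82 log units; beyond the scatter), and this step joins two true numbers, so the link between chain length and a lower number at this position no longer rests on a limit alone. Among the compounds shown here, the widest change in chain length gives an at least 33-fold lower number from compound 3 to compound 4 (1.52 log units; beyond the scatter), which points the same way, and over these three chain lengths the number falls as the chain grows, with no compound going against it. Compound 3 reads only as a limit and not as a number, so that second step has no exact size: the limit of > 100000 nM in this assay, at which 1 of the 4 values shown sits.

Going by these compounds, how the number moves at chain lengths between those of compound 2 and compound 4 stays open, as does whether a still longer chain would lower it further. Also open, on these data alone, is what a carboxylic acid in place of the hydroxycarbamoyl end would give.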